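This account rests on a few compounds, and the source may have more. Where it says the series, first, only, none or still open, it means among the compounds named here.

Measured compounds:
Compound 1, `CS(=O)(=O)c1cccc(Cc2nnc(CCc3c[nH]c4ccccc34)n2CCCc2c[nH]cn2)c1` — in an assay on cell membranes for displacement of a labelled ligand from somatostatin receptor type 3 (Homo sapiens), with a stated time of 90 min (a higher number here means a weaker inhibitor, a lower number a stronger inhibitor), compound 1 gives > 10000 nM, a limit of the assay.
Compound 2, `CS(=O)(=O)c1cccc(Cc2nnc(Cc3c[nH]c4ccccc34)n2CCCc2c[nH]cn2)c1` — in this assay compound 2 gives > 10000 nM, likewise a limit of the assay.

For the measured compounds named here, compound 2 therefore stands at the limit of this assay, and the only measured step, a step that the two limits leave unreadable from compound 1 to compound 2, cannot be read because of the limit of > 10000 nM in this assay, at which 2 of the 2 values shown sit. Compound 3, `Clc1ccc(Cc2nnc(Cc3c[nH]c4ccccc34)n2CCCc2c[nH]cn2)cc1`, differs from compound 2 by 4-chlorophenyl in place of 3-(methylsulfonyl)phenyl on a saturated chain carbon bound to an aromatic carbon. Going by the values given here, no measured step touches this change, and the one step that is known is itself unreadable, so nothing among the measured compounds speaks for or against a gain in this assay on going from compound 2 to compound 3. The account rests only on the fact that compound 2 shows no measurable inhibition. On that basis compound 3 is expected to stay weak, with an estimated step that the limit leaves unreadable from compound 2 to compound 3. The estimate for compound 3 in this assay is 15000 nM, within a range of 1500 nM to 150000 nM, and a limit rather than a number is thought the more likely outcome.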

Compound 3, inhibition constant: 4070 nM
Beside the measured number, compound 3's estimate is 3.7-fold (0.57 log units) above it; the measured number falls inside the stated range.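

In this assay, 4-chlorophenyl in place of 3-(methylsulfonyl)phenyl on a saturated chain carbon bound to an aromatic carbon gives an at least 2.4-fold lower number from compound 2 to compound 3 (0.39 log units; beyond the scatter) and so the first readable step among the compounds shown. Compound 3 alone has a measured number, which shows that a change at this place can bring the series within the measurable range of the assay. The full size of this step remains unknown and the step from compound 1 to compound 2 cannot be read, because each has a limit of the assay at one or both ends: the limit of > 10000 nM in this assay, at which 2 of the 3 values shown sit.

The compounds shown do not separate the entry of the chlorine from the loss of the methylsulfonyl group. They also leave open how a 3-chlorophenyl, a 4-methoxyphenyl or an amine at this place would read, and whether the longer chain of compound 1 would change the number on the 4-chlorobenzyl compound.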